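Caffeic ester and amide triazoles on prostate cancer cells

The compounds below may be only part of what the source reports. "The series", "measured", "known", "first", "only" and "open" are said of these compounds alone.

Measured so far:
compound 1 `CS(=O)(=O)c1ccc(-c2nc(SCCOC(=O)/C=C/c3ccc(O)c(O)c3)nn2-c2ccccc2)cc1`: 14600 nM
compound 2 `CC(=O)Oc1ccc(/C=C/C(=O)NCCCSc2nc(-c3ccc(S(C)(=O)=O)cc3)n(-c3ccc(Br)cc3)n2)cc1OC(C)=O`: 23900 nM

In a functional assay on PC-3 cells (Homo sapiens) for antiproliferative activity, read by MTT assay, with a stated time of 72 h (a higher number here means a weaker inhibitor, a lower number a stronger inhibitor), compound 1 gives 14600 nM. In this assay compound 2 gives 23900 nM. Compound 2 holds the highest of the two numbers, but its nearest neighbour is compound 1, and the gap between the two lies within the scatter, so no order between them can be read. The two compounds differ in several places at once, and nothing beyond their two values can be said of the pair.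

Compound 3 `CC(=O)Oc1ccc(/C=C/C(=O)NCCCSc2nc(-c3ccc(S(C)(=O)=O)cc3)n(-c3ccc(F)cc3)n2)cc1OC(C)=O` is not yet measured. It differs from compound 2 in one place: fluoro in place of bromo on an aromatic carbon. Among the measured compounds shown here, no step between measured compounds with this change is available, so no direction can be drawn from the data; the change is small and the step is expected to stay within the scatter. For compound 3 the estimate in this assay is 25000 nM, with a range from 10000 nM to 60000 nM. The estimated step of a 1.0-fold higher number from compound 2 to compound 3 (0.02 log units; within the scatter) is expected to be negligible.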

Compound 3, half-maximal inhibitory concentration: 17600 nM
For compound 3 the middle estimate is 1.4-fold (0.15 log units) above the measured one; measured number inside the range.
By their numbers in this assay, from the lowest: compounds 1, 3 and 2 (each within the scatter of the next).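

In this assay the series now has its first comparison that isolates one place, the change from 4-bromophenyl to 4-fluorophenyl (a 1.4-fold lower number from compound 2 to compound 3 (0.13 log units; within the scatter)). On this aromatic carbon, para to a large group, fluoro and bromo therefore cannot be told apart by the antiproliferative read-out, so between these two halogens the identity of the atom does not register in the values, which the earlier pair, differing in several places at once, could not show. No measurement at hand offers a reason for this flat step or bears on the result.

Still open, going by these compounds, is whether a group of a different kind in this place, such as an amine, a methoxy or a carboxylic acid, would give a step beyond the scatter, or whether this position tolerates any substituent in the same way. Among the compounds shown here, also open is what each of the other differences between compound 1 and compound 2 contributes on its own, among them the amide and ester links, the acetyl groups and the length of the chain, since no single-place step separates them.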